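Ethylamino to 4-methylpiperazin-1-yl on the shared core

The source may hold more compounds than are shown below. What is called first, only, known or untested is meant among the compounds shown, and "the series" means these compounds.

Compound 1 `CCNc1nc(SCc2nc3ccccc3[nH]2)nc(-c2ccccc2)c1C#N`: 4.38 nM
Compound 2 `N#Cc1c(Nc2nccs2)nc(SCc2nc3ccccc3[nH]2)nc1-c1ccccc1`: 14.7 nM
Compound 3 `N#Cc1c(NNC(N)=S)nc(SCc2nc3ccccc3[nH]2)nc1-c1ccccc1`: 8.9 nM

In a functional assay on K562 cells (Homo sapiens) for cytotoxicity, read by MTT assay, with a stated time of 3 days (on this read-out higher numbers stand for weaker inhibition and lower numbers for stronger inhibition), compound 1 holds the lowest number of the three, and its steps to the other two lie beyond the scatter. Compound 4 `CN1CCN(c2nc(SCc3nc4ccccc4[nH]3)nc(-c3ccccc3)c2C#N)CC1` differs from it by 4-methylpiperazin-1-yl in place of ethylamino on an aromatic carbon, which is 4-methylpiperazin-1-yl in place of ethylamino on an aromatic carbon. Two measured changes at this place bear on it: a 3.4-fold higher number from compound 1 to compound 2 (0.53 log units; beyond the scatter) and a 2.0-fold higher number from compound 1 to compound 3 (0.31 log units; beyond the scatter). Both are modest and both go upward, while a 1.7-fold lower number from compound 2 to compound 3 (0.22 log units; within the scatter) stays within the scatter. Among the measured compounds shown here, no measured compound carries a non-aromatic ring here, so the range stays wide. A modest upward step of similar size is therefore expected in this assay. The expected change is a 2.7-fold higher number from compound 1 to compound 4 (0.44 log units; beyond the scatter). For compound 4 the estimated value is 12 nM, with an expected range of 4 nM to 36 nM.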

Compound 4, half-maximal inhibitory concentration: 2.4 nM
Compound 4: the middle estimate sits 5.0-fold (0.70 log units) above what was measured; measured number below the stated range.
By their numbers in this assay, from the lowest: compounds 4 and 1 (each within the scatter of the next); then compounds 3 and 2 (each within the scatter of the next).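

The step of a 1.8-fold lower number from compound 1 to compound 4 (0.26 log units; within the scatter) in this assay shows that this aromatic carbon accepts a six-membered non-aromatic ring, with no change beyond the scatter when the hydrogen-bond donor of ethylamino is lost. The same ring group stands apart from the two other replacements, with a 3.7-fold lower number from compound 3 to compound 4 (0.57 log units; beyond the scatter) and a 6.1-fold lower number from compound 2 to compound 4 (0.79 log units; beyond the scatter) as the steps. No measurement shown here accounts for these steps.

Still open, going by these compounds, is whether the methyl or the second ring nitrogen of 4-methylpiperazin-1-yl matters. Piperazin-1-yl, morpholin-4-yl and piperidin-1-yl at this carbon would separate those parts from the ring itself.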